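The compounds below may be only part of what the source reports. "The series", "measured", "known", "first", "only" and "open" are said of these compounds alone.

In an assay on HEK293 cells for agonist activity at transient receptor potential cation channel subfamily M member 8 (Homo sapiens), read by fluorescence and calcium flux, with a stated time of 15 min (on this read-out lower numbers stand for an effect already at smaller amounts and higher numbers for an effect only at larger amounts of compound), compound 3 `Cc1ccc(OCC(=O)N(Cc2cccs2)c2c(C)n[nH]c2C)cc1` gives 0.3 nM, the lowest of the three numbers, though compound 1 `Cc1ccc(OCC(=O)N(Cc2cccs2)c2c[nH]nc2C)cc1` with 0.4 nM lies within the scatter of it. Compound 2 `C=CCN(Cc1cccs1)C(=O)COc1ccc(C)cc1` gives 20 nM. Compound 4 `Cc1ccc(OCC(=O)N(Cc2cccs2)c2ncco2)cc1` has not yet been measured; it differs from compound 3 by 1,3-oxazol-2-yl in place of 3,5-dimethyl-1H-pyrazol-4-yl on an amide-type nitrogen. Among the compounds with values here, the steps that bear on this change are a 50-fold higher number from compound 1 to compound 2 (1.70 log units; beyond the scatter) and a 67-fold lower number from compound 2 to compound 3 (1.82 log units; beyond the scatter), both showing that what sits on the amide-type nitrogen matters greatly. Swapping the 3,5-dimethyl-1H-pyrazol-4-yl for another five-membered aromatic ring, one without a hydrogen-bond donor, is expected to cost some potency, but less than the allyl did. Compound 4 is therefore expected at 5 nM, between 1 nM and 30 nM, which means a 17-fold higher number from compound 3 to compound 4 (1.22 log units; beyond the scatter).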

Compound 4, half-maximal effective concentration: 0.3 nM
The estimate for compound 4 lay 17-fold (1.22 log units) above the measured number; measured number outside the range, below it.
By their numbers in this assay, from the lowest: compounds 3, 4 and 1 (each within the scatter of the next); then compound 2.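

The 1,3-oxazol-2-yl ring has no hydrogen-bond donor and fewer heavy atoms than 3,5-dimethyl-1H-pyrazol-4-yl, yet in this assay this change shows no change at the digits printed from compound 3 to compound 4 (within the scatter), so a donor on this ring is not required for a low number here. The comparison with the other pyrazole gives a 1.3-fold lower number from compound 1 to compound 4 (0.12 log units; within the scatter), while replacing allyl gives a 67-fold lower number from compound 2 to compound 4 (1.82 log units; beyond the scatter). No measurement available here explains why these rings match. Going by these compounds, what a pyridin-2-yl ring, or a saturated chain carrying an amine, would give on this nitrogen stays open.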